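A few compounds are considered here, and "the series" means these few. Any claim that something is new, unique, unknown or untested is made for them only; others in the source may bear on it.

Compounds in this series share one core and differ in the amide at the end of a chain. Among the compounds with values here, in a functional assay on FaDu cells (Homo sapiens) for antiproliferative activity, read by sulforhodamine B assay, with a stated time of 48 h (a higher number here means a weaker inhibitor, a lower number a stronger inhibitor), compound 2 `CCCCN(C)C(=O)CCCCOc1cc(OC)c(OC)c2oc(-c3ccc(OC)cc3)c(O)c(=O)c12` gives 22000 nM, the only actual number so far. Compound 1 `COc1ccc(-c2oc3c(OC)c(OC)cc(OCCCC(=O)NCc4ccccn4)c3c(=O)c2O)cc1` gives > 40000 nM, which is a limit of the assay. Compound 3 `COc1ccc(-c2oc3c(OC)c(OC)cc(OCCCCC(=O)N4CCN(C)CC4)c3c(=O)c2O)cc1` gives > 40000 nM, which is also a limit.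

Compound 4 `COc1ccc(-c2oc3c(OC)c(OC)cc(OCCCCCC(=O)N4CCN(C)CC4)c3c(=O)c2O)cc1` differs from compound 2 by one change: ((4-methylpiperazin-1-yl)carbonyl)methyl in place of butyl(methyl)carbamoyl on a saturated chain carbon, four bonds along the chain from an oxygen on an aromatic ring. In words, ((4-methylpiperazin-1-yl)carbonyl)methyl replaces butyl(methyl)carbamoyl on a saturated chain carbon, four bonds along the chain from an oxygen on an aromatic ring.

The closest measured change puts 4-methylpiperazin-1-yl in place of butyl(methyl)amino on a carbonyl carbon, and it gives an at least 1.8-fold higher number from compound 2 to compound 3 (0.25 log units; that floor lies within the scatter). Its size is only a floor, and the other limit is the same: the limit of > 40000 nM in this assay, at which 2 of the 3 values shown sit. On that basis, a small move towards a higher number is expected, and the result may again be only a limit. The expected step is a 1.6-fold higher number from compound 2 to compound 4 (0.20 log units; within the scatter). For compound 4 the estimated value is 35000 nM, with an expected range of 14000 nM to 80000 nM.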

Compound 4, half-maximal inhibitory concentration: 15800 nM
Estimate against measurement, compound 4: 2.2-fold (0.35 log units) above; measured number inside the range.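

In this assay, lengthening the chain that carries the 4-methylpiperazin-1-yl amide gives an at least 2.5-fold lower number from compound 3 to compound 4 (0.40 log units; beyond the scatter), so with this amide the chain length at this position makes a readable difference. Setting 2-((4-methylpiperazin-1-yl)carbonyl)ethyl in place of ((pyridin-2-yl)methyl)carbamoyl gives an at least 2.5-fold lower number from compound 1 to compound 4 (0.40 log units; beyond the scatter). Replacing butyl(methyl)carbamoyl with ((4-methylpiperazin-1-yl)carbonyl)methyl gives a 1.4-fold lower number from compound 2 to compound 4 (0.14 log units; within the scatter), so the two groups cannot be told apart here, and the 4-methylpiperazin-1-yl amide on this longer chain does as well as the butyl(methyl) amide on the shorter one.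

As far as these compounds go, the true size of the first two steps stays open, as each is only a floor set by a limit: the limit of > 40000 nM in this assay, at which 2 of the 4 values shown sit. Whether a still longer chain, or a carboxylic acid in place of the amide, would give a lower number also remains open.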